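Replacing a Trifluoromethylphenyl Group with a Fluorophenyl Group

A few compounds are considered here, and "the series" means these few. Any claim that something is new, unique, unknown or untested is made for them only; others in the source may bear on it.

Of the compounds shown here, two sharing one core have been measured in an assay on HEK293 cells for inhibition of Voltage-dependent T-type calcium channel subunit alpha-1G (Homo sapiens), read by fluorescence, tested at 10 uM; a lower number here means less inhibition, a higher number more inhibition at the concentration tested (going by the name of the read-out). Compound 1 `CCCc1nc(-c2ccccc2)c(CNCCN2CCN(c3ccc(Cl)cc3)CC2)o1` gives 55.8% in this assay. Compound 2 `CCCc1nc(-c2ccccc2)c(CNCCN2CCN(c3cccc(C(F)(F)F)c3)CC2)o1`, carrying a 3-(trifluoromethyl)phenyl in place of the 4-chlorophenyl, gives 56.3% in this assay. The step of a number 0.5 percentage points higher from compound 1 to compound 2 (within the scatter) lies within the scatter, so compound 2 holds the higher of the two numbers only nominally; the two values cannot be told apart.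

Compound 3 `CCCc1nc(-c2ccccc2)c(CNCCN2CCN(c3ccccc3F)CC2)o1` has not yet been measured. It differs from compound 2 as follows: 2-fluorophenyl in place of 3-(trifluoromethyl)phenyl on an amine nitrogen in a ring. Among the compounds with values here, the single measured step, a number 0.5 percentage points higher from compound 1 to compound 2 (within the scatter), exchanged one substituted phenyl for another on the same ring nitrogen and hardly moved the number. Within the data shown here, that step bears on the present change, since again one substituted phenyl is exchanged for another at that position, but no measured pair shows what a 2-fluorophenyl does there, so the uncertainty is wider than a single repeat would suggest. For compound 3 the step of a number 4.3 percentage points lower from compound 2 to compound 3 (within the scatter) is expected to stay within the scatter. The estimate for compound 3 is 52%, within a range from 32% to 70%.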

Compound 3, a percentage reported as inhibition, at one concentration (the size of the read-out at that concentration, not a potency): 46.5%
Estimate against measurement, compound 3: 5.5 percentage points above, and the stated range covers the measured number.
By their numbers in this assay, from the lowest: compounds 3, 1 and 2 (each within the scatter of the next).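

In this assay, the 2-fluorophenyl on the amine nitrogen in the ring gives a number 9.8 percentage points lower from compound 2 to compound 3 (within the scatter) and a number 9.3 percentage points lower from compound 1 to compound 3 (within the scatter), and both steps lie within the usual scatter of repeated measurements. Within the data shown here, the earlier pair showed this for only two substituted phenyl groups; all three compounds now cannot be told apart, even though the 2-fluorophenyl has fewer heavy atoms than the 3-(trifluoromethyl)phenyl it replaces. So at this position, the read-out at this single test concentration does not separate these three substituted phenyl groups, and nothing measured here explains why.

The compounds shown leave open whether the number stays level beyond halogen-bearing phenyl groups, for example with a plain unsubstituted phenyl, a methoxyphenyl, or a carboxylic acid on the phenyl ring. They also leave open whether replacing the phenyl with a simple alkyl chain would give a number clearly outside the scatter, which would show that the ring on this nitrogen matters at all.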